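Naphthyl replaces methoxyphenoxy on the shared core

The compounds below may be only part of what the source reports. "The series", "measured", "known", "first", "only" and "open" are said of these compounds alone.

Compound 1, `Cc1cc(C)cc(Cc2ccc3c(NCCCNCc4ccco4)ccnc3c2)c1`, gives 9.47 in a physicochemical assay for acid dissociation.
Compound 2, `Fc1ccc(Cc2ccc3c(NCCCNCc4ccco4)ccnc3c2)cc1`, gives 9.47 in this assay.
Compound 3, `COc1ccccc1Oc1ccc2c(NCCCNCc3ccco3)ccnc2c1`, gives 9.28 in this assay.

Compound 3 holds the lowest of the three numbers, but its gap to compound 1 and to compound 2 lies within the scatter, so the three compounds cannot be ordered. The steps that have been measured are no change at the digits printed from compound 1 to compound 2 (within the scatter), a number 0.19 log units lower from compound 1 to compound 3 (within the scatter) and a number 0.19 log units lower from compound 2 to compound 3 (within the scatter); each of them exchanges the group on the aromatic carbon of the shared core and none of them moves the number beyond the scatter.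

Compound 4 is `c1coc(CNCCCNc2ccnc3cc(-c4cccc5ccccc45)ccc23)c1`. Compared with compound 3 it changes as follows: naphthalen-1-yl in place of 2-methoxyphenoxy on an aromatic carbon. The change again sits on the same aromatic carbon of the core that was varied in the measured steps, and the chain carrying the amines is left untouched. Because a number 0.19 log units lower from compound 1 to compound 3 (within the scatter) and a number 0.19 log units lower from compound 2 to compound 3 (within the scatter) stayed within the scatter when that position was altered, no step beyond the scatter is expected here either. Compound 4 is therefore estimated at 9.4, with a range from 9.1 to 9.7. The step this estimate implies, a number 0.12 log units higher from compound 3 to compound 4 (within the scatter), is expected to fall within the usual scatter.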

Compound 4, acid dissociation constant: 9.47
Compound 4: the middle estimate sits 0.07 log units below what was measured; the measured number falls inside the stated range.
By their numbers in this assay, from the lowest: compounds 3, 1, 2 and 4 (each within the scatter of the next).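

Naphthalen-1-yl brings 2 six-membered aromatic rings of carbon only and 0 hydrogen-bond acceptors to this aromatic carbon, where 2-methoxyphenoxy had one such ring and 2 hydrogen-bond acceptors, and the result in this assay is a number 0.19 log units higher from compound 3 to compound 4 (within the scatter) and no more. Set against the two benzyl groups, the same group gives no change at the digits printed from compound 2 to compound 4 (within the scatter) and no change at the digits printed from compound 1 to compound 4 (within the scatter) so that this exchange leaves the number where those groups had it. Across the four groups shown on this carbon, then, even this larger all-carbon group with two fused rings does not separate one compound from another in this assay and the four cannot be ordered.

From the compounds shown here alone, it remains open whether an amine or a carboxylic acid on this same carbon, or a longer chain between the two amines, would move the number beyond the scatter. Nothing available gives a reason why the number holds across these groups on this carbon.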